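The source may hold more compounds than are shown below. What is called first, only, known or untested is meant among the compounds shown, and "the series" means these compounds.

Measured so far:
Compound 1, `COc1cc2cc(Oc3ccc(NC(=O)Nc4ccc(C)cc4)cc3)c(C)nc2cc1OC`: 113%
Compound 2, `COc1cc2cc(Oc3ccc(NC(=O)Nc4cccc(C(F)(F)F)c4)cc3)c(C)nc2cc1OC`: -0.54%

Both compounds were tested in a functional assay on OVCAR-3 cells (Homo sapiens) for inhibition, read by sulforhodamine B assay, with a stated time of 48 h, tested at 10 uM; a higher number here means a weaker effect of the compound at the concentration tested, a lower number a stronger effect. Compound 1 gives 113% in this assay, the highest of the two numbers; the nearest to it is compound 2, which gives -0.54%. For the measured compounds named here, the only step measured so far, a number 113.5 percentage points lower from compound 1 to compound 2 (beyond the scatter), is large and lies beyond the scatter.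

Compound 3, `COc1cc2cc(Oc3ccc(NC(=O)Nc4ccc(Cl)c(C(F)(F)F)c4)cc3)c(C)nc2cc1OC`, has not yet been measured in this assay. It differs from compound 1 in one place: 4-chloro-3-(trifluoromethyl)phenyl in place of 4-methylphenyl on an amide-type nitrogen. Going by the values given here, the group that enters carries the trifluoromethyl also found in the corresponding group of compound 2, together with a chlorine; no measured step covers that chlorine on its own, so its contribution is unknown. Among the compounds with values here, the one step that bears on the change, a number 113.5 percentage points lower from compound 1 to compound 2 (beyond the scatter), was large and downward. A step of similar size and direction is therefore expected for compound 3 in this assay, a number 108 percentage points lower from compound 1 to compound 3 (beyond the scatter). Compound 3 is thus expected to give 5% in this assay, within a range from -15% to 35%.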

Compound 3, a percentage reported as activity, at one concentration (the size of the read-out at that concentration, not a potency): -27.3%
Estimate against measurement, compound 3: 32.3 percentage points above; measured number below the stated range.
By their numbers in this assay, from the lowest: compound 3; then compound 2; then compound 1.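

For the compounds shown here, the chlorine, whose contribution the earlier compounds left unknown, proves measurable: in this assay, chloro in place of hydrogen on an aromatic carbon gives a number 26.8 percentage points lower from compound 2 to compound 3 (beyond the scatter), a modest step but one beyond the scatter. This position on the amide-type nitrogen therefore still responds to change after the trifluoromethyl is present, and the full replacement of 4-methylphenyl by 4-chloro-3-(trifluoromethyl)phenyl gives a number 140.3 percentage points lower from compound 1 to compound 3 (beyond the scatter), which places compound 3 lowest of the three and gives it the strongest effect at the concentration tested. Nothing measured here gives a reason for either step.

The compounds shown do not separate the loss of the methyl from the gain of the trifluoromethyl and chloro groups, and a 4-chlorophenyl group would show whether chlorine has a comparable effect without the trifluoromethyl. As far as these compounds go, it also remains open whether a nitrile or a methoxy group in place of the chlorine would give a similar step, and since all the numbers come from a single concentration, they say nothing about potency.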